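The compounds below may be only part of what the source reports. "The series", "measured", "known", "first", "only" and "open" are said of these compounds alone.

In a functional assay on HT-1080 cells (Homo sapiens) for cytotoxicity, read by MTT assay, with a stated time of 72 h (on this read-out lower numbers stand for stronger inhibition and higher numbers for weaker inhibition), three compounds on the shared core have been measured. Compound 1 (`COc1cccc(/C=C2\CCC/C(=C\c3cccc(Br)c3)C2=O)c1OC`) gives 12200 nM there and compound 2 (`COc1cccc(/C=C2\CCC/C(=C\c3cccc(OC)c3OC)C2=O)c1`) gives 9900 nM there too. Compound 3 (`COc1ccc(/C=C2\CCC/C(=C\c3ccccc3Cl)C2=O)cc1OC`) gives 6800 nM and so stands within the scatter of both. Compound 4 (`COc1ccc(/C=C2\CCC/C(=C\c3ccc(OC)c(OC)c3)C2=O)cc1`) departs from compound 3 as 4-methoxyphenyl in place of 2-chlorophenyl on a double-bonded chain carbon bound to a double-bonded ring carbon with 4-methoxyphenyl in place of 2-chlorophenyl on a double-bonded chain carbon bound to a double-bonded ring carbon. Going by the values given here, the one measured step is a 1.2-fold lower number from compound 1 to compound 2 (0.09 log units; within the scatter) for methoxy in place of bromo on an aromatic carbon, a different exchange within the scatter, so no step beyond the scatter is expected in this assay for this change. The estimated step is a 1.3-fold higher number from compound 3 to compound 4 (0.10 log units; within the scatter) and stays inside the scatter. For compound 4 the expected value is 8500 nM within an estimated range from 3500 nM to 20000 nM overall.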

Compound 4, half-maximal inhibitory concentration: 7200 nM
For compound 4 the middle estimate is 1.2-fold (0.07 log units) above the measured one; low and high end bracket the measured number.
By their numbers in this assay, from the lowest: compounds 3, 4, 2 and 1 (each within the scatter of the next).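

With the other side of the shared core held constant, a 1.1-fold higher number from compound 3 to compound 4 (0.02 log units; within the scatter) in this assay when 4-methoxyphenyl replaces 2-chlorophenyl on a double-bonded chain carbon bound to a double-bonded ring carbon. This position therefore shows no step beyond the scatter for an exchange of the whole substituted phenyl, including one that brings a hydrogen-bond acceptor where the leaving group has none. No evidence here accounts for this result. Going by these compounds, what stays open is whether an amine or a carboxylic acid on this phenyl, or a longer chain in its place, would give a step beyond the scatter.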